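Fluoro for ethynyl on the aryl ring of a thiazolidinone amide

This account rests on a few compounds, and the source may have more. Where it says the series, first, only, none or still open, it means among the compounds named here.

Compound 1 `COc1ccccc1N1C(=O)CSC1c1cc(F)cc(C(=O)NCCCCc2ccccc2)c1`: 10000 nM
Compound 2 `C#Cc1cc(C(=O)NCCCCc2ccccc2)cc(C2SCC(=O)N2c2ccccc2OC)c1`: 10000 nM
Compound 3 `C#Cc1cccc(N2C(=O)CSC2c2cccc(C(=O)NCCCCc3ccccc3)c2)c1`: 10000 nM

Of the compounds shown here, three have been measured in a physicochemical assay for solubility, read by turbidimetry, measured as kinetic solubility, at pH 6.8; a higher number here means a more soluble compound, a lower number a less soluble compound. Compound 1 `COc1ccccc1N1C(=O)CSC1c1cc(F)cc(C(=O)NCCCCc2ccccc2)c1` gives 10000 nM, compound 2 `C#Cc1cc(C(=O)NCCCCc2ccccc2)cc(C2SCC(=O)N2c2ccccc2OC)c1` gives 10000 nM, and compound 3 `C#Cc1cccc(N2C(=O)CSC2c2cccc(C(=O)NCCCCc3ccccc3)c2)c1` gives 10000 nM. Compound 2 and compound 1 differ in one place, (fluoro in place of ethynyl on an aromatic carbon), and the step is no change at the digits printed from compound 2 to compound 1 (within the scatter). Compound 4 `O=C(NCCCCc1ccccc1)c1cccc(C2SCC(=O)N2c2cccc(F)c2)c1` is not yet measured; it stands to compound 3 as compound 1 stands to compound 2, by fluoro in place of ethynyl on an aromatic carbon. The place differs: in compound 2 the ring carbon is meta to two large groups, in compound 3 meta to a large group, so this is the same kind of change rather than the same change. The difference between the two cores is not broken down here. Since the measured step from compound 2 to compound 1 stayed within the scatter, the step from compound 3 to compound 4 is expected to be no change at the digits printed from compound 3 to compound 4 (within the scatter). Compound 4 is therefore estimated at 10000 nM.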

Compound 4, solubility: 10000 nM
Beside the measured number, compound 4's estimate shows no gap at the digits printed; measured number inside the range.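

In this assay, fluoro in place of ethynyl gave no change at the digits printed from compound 3 to compound 4 (within the scatter), in line with no change at the digits printed from compound 2 to compound 1 (within the scatter), so this kind of change read the same on two different cores. Among these compounds, this shows agreement across only two pairs, both with no measurable step, and it does not show that the change would stay silent on other cores or at other places on the ring. Nothing available explains why the two steps agree.

The compounds shown leave open whether an amine or a carboxylic acid in place of the fluoro would give a different reading in this assay. They also leave open what a longer chain on the amide would do.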